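This account rests on a few compounds, and the source may have more. Where it says the series, first, only, none or still open, it means among the compounds named here.

In a functional assay on A549 cells (Homo sapiens) for inhibition, read by MTT assay, with a stated time of 72 h (a higher number here means a weaker inhibitor, a lower number a stronger inhibitor), compound 3 (`COc1cc(O)c(CC=C(C)C)c(O)c1C(=O)/C=C/c1ccc([N+](=O)[O-])cc1`) gives 31200 nM, within the scatter of compound 1 (`COc1ccc(/C=C/C(=O)c2c(OC)cc(O)c(CC=C(C)C)c2O)cc1`) at 38000 nM and higher than compound 2 (`COc1cc(/C=C/C(=O)c2c(OC)cc(O)c(CC=C(C)C)c2O)ccc1O`) at 11800 nM. Compound 4 (`COc1cc(O)cc(O)c1C(=O)/C=C/c1ccc([N+](=O)[O-])cc1`) differs from compound 3 by hydrogen in place of 3-methylbut-2-en-1-yl on an aromatic carbon. For the measured compounds named here, no measured step touches that group. a 3.2-fold lower number from compound 1 to compound 2 (0.51 log units; beyond the scatter), a 1.2-fold lower number from compound 1 to compound 3 (0.09 log units; within the scatter) and a 2.6-fold higher number from compound 2 to compound 3 (0.42 log units; beyond the scatter) all concern the group on the double-bonded chain carbon, so they guide size only, and none gives a direction. A modest rise in this assay is assumed, with the direction uncertain. The expected step is a 1.6-fold higher number from compound 3 to compound 4 (0.20 log units; within the scatter). Compound 4 is estimated at 50000 nM, with an expected range of 18000 nM to 130000 nM.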

Compound 4, half-maximal inhibitory concentration: > 50000 nM
Compound 4 ended at the assay's limit (the forecaster's own chance of this, stated with the estimate: 20%); the middle value lies on the limit itself.
By their numbers in this assay, from the lowest: compound 2; then compounds 3 and 1 (each within the scatter of the next). At a limit, above all of these: compound 4.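

In this assay, hydrogen in place of 3-methylbut-2-en-1-yl on the aromatic carbon gives an at least 1.6-fold higher number from compound 3 to compound 4 (0.20 log units; that floor lies within the scatter). For the compounds shown here, this is the first reading at this position, but it sets only a floor, and that floor does not clear the scatter. Compound 4 stands at a limit, not at a number: the limit of > 50000 nM in this assay, at which 1 of the 4 values shown sits.

On these data alone, the true size of the step stays open, as does whether a methyl group, a longer chain or an amine at this carbon would keep the number of compound 3. Also open, as far as these compounds go, is whether the same change on compound 2 would act alike.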